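A few compounds are considered here, and "the series" means these few. Any claim that something is new, unique, unknown or untested is made for them only; others in the source may bear on it.

Measured in a functional assay for inhibition, with Homo sapiens as the target; a lower number here means a stronger inhibitor, a higher number a weaker inhibitor:
Compound 1 `CC(C)(C)Sc1c(CC(C)(C)C(=O)O)n(Cc2ccc(Cl)cc2)c2ccc(OCc3ccc4cc(F)ccc4n3)cc12`: 2 nM
Compound 2 `COc1ccc2nc(COc3ccc4c(c3)c(SC(C)(C)C)c(CC(C)(C)C(=O)O)n4Cc3ccc(Cl)cc3)sc2c1`: 8 nM
Compound 3 `CC(C)(C)Sc1c(CC(C)(C)C(=O)O)n(Cc2ccc(Cl)cc2)c2ccc(OCc3cccnc3)cc12`: 8 nM

The three compounds share a core and differ only in the group on a saturated chain carbon bound to an oxygen on an aromatic ring. Compound 3, at 8 nM, stands level with compound 2 and shares with it the highest number of the three, while compound 1 is the most potent.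

The next compound, compound 4 `C[C@H](COc1ccc2c(c1)c(SC(C)(C)C)c(CC(C)(C)C(=O)O)n2Cc1ccc(Cl)cc1)c1ccccn1`, has not yet been measured. It carries 1-(pyridin-2-yl)ethyl in place of pyridin-3-yl at that same place: 1-(pyridin-2-yl)ethyl in place of pyridin-3-yl on a saturated chain carbon bound to an oxygen on an aromatic ring.

Among the measured compounds shown here, none of the measured compounds carries this group, so no measured step covers the change directly. The nearest evidence is the set of steps at the same place. There is a modest 4.0-fold higher number from compound 1 to compound 3 (0.60 log units; beyond the scatter) and an equally modest a 4.0-fold higher number from compound 1 to compound 2 (0.60 log units; beyond the scatter), whereas no change at the digits printed from compound 2 to compound 3 (within the scatter) stays within the scatter. Swaps among quite different groups at this place have therefore moved this assay only modestly, and a step beyond the scatter is not expected here, though either direction remains possible.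

The expected change is a 1.3-fold higher number from compound 3 to compound 4 (0.10 log units; within the scatter). For compound 4 the estimated value is 10 nM, with an expected range from 3 nM to 35 nM.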

Compound 4, half-maximal inhibitory concentration: 3 nM
Beside the measured number, compound 4's estimate is 3.3-fold (0.52 log units) above it; low and high end bracket the measured number.
By their numbers in this assay, from the lowest: compounds 1 and 4 (each within the scatter of the next); then compounds 2 and 3 (each within the scatter of the next).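

In this assay, 1-(pyridin-2-yl)ethyl on a saturated chain carbon bound to an oxygen on an aromatic ring gives a 2.7-fold lower number from compound 3 to compound 4 (0.43 log units; beyond the scatter) and a 2.7-fold lower number from compound 2 to compound 4 (0.43 log units; beyond the scatter), both beyond the scatter, while a 1.5-fold higher number from compound 1 to compound 4 (0.18 log units; within the scatter) stays within it, so a number in the range of compound 1 is no longer tied to 6-fluoroquinolin-2-yl and is also reached with a group carrying one six-membered aromatic ring. Pyridin-3-yl and 1-(pyridin-2-yl)ethyl each have one such ring with one hetero atom and match in their counts of hydrogen-bond donors and acceptors, yet compound 3 and compound 4 still lie apart beyond the scatter, so those shared counts alone do not fix the number at this place. Nothing in hand gives a reason for these shifts.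

Compound 4 changes the point of attachment of the pyridine, the size of the group and the presence of a defined stereocentre in a single step, and the four compounds do not separate these changes. Plain pyridin-2-yl at this place and the opposite stereoisomer of 1-(pyridin-2-yl)ethyl lie outside the compounds shown, as do a phenyl ring and an amine, so how each part of the group contributes remains open.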